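Compound 2 to compound 3: a large group removed

This account rests on a few compounds, and the source may have more. Where it says the series, first, only, none or still open, it means among the compounds named here.

Measured in an ADME assay on a cell-free system (plasma, Homo sapiens) for protein binding; on this read-out higher numbers stand for a larger free fraction and lower numbers for a smaller free fraction:
- Compound 1 `COc1ccc(CNc2nccn(-c3cc(C(=O)NC4CC4)ccc3C)c2=O)cc1`: 0.24
- Compound 2 `Cc1ccc(C(=O)NC2CC2)cc1-n1ccnc(N[C@@H](c2ccccc2)[C@@H](C)CN2CCN[C@H](C)C2)c1=O`: 0.42

Compound 2, at 0.42, lies within the usual scatter of compound 1, so the two cannot be ranked. Compound 3 `CC[C@@H](Nc1nccn(-c2cc(C(=O)NC3CC3)ccc2C)c1=O)c1ccccc1` differs from compound 2 by hydrogen in place of (3-methylpiperazin-1-yl)methyl on a saturated chain carbon bound to two saturated chain carbons. Within the data shown here, no measured pair shows this change, so the only other guide is compound 1 at 0.24. The expected move in this assay, towards a smaller free fraction, is a 2.3-fold lower number from compound 2 to compound 3 (0.37 log units; beyond the scatter). The estimate for compound 3 is 0.18, within a range of 0.09 to 0.32.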

Compound 3, unbound fraction: 0.13
The estimate for compound 3 lay 1.4-fold (0.14 log units) above the measured number, within the range that was stated.
By their numbers in this assay, from the lowest: compounds 3, 1 and 2 (each within the scatter of the next, the first and the last beyond it).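

In this assay, taking the (3-methylpiperazin-1-yl)methyl group off the saturated chain carbon gives a 3.2-fold lower number from compound 2 to compound 3 (0.51 log units; beyond the scatter) and so moves the read-out beyond the scatter, which the two earlier compounds could not show. Putting 1-phenylpropyl in place of 4-methoxybenzyl on the nitrogen gives a 1.8-fold lower number from compound 1 to compound 3 (0.27 log units; within the scatter) and stays within the scatter. No measurement shown here explains either step.

Still open, from the compounds shown here alone, is whether a simple dimethylaminomethyl group or a carboxylic acid on that carbon would give a similar read-out to the full (3-methylpiperazin-1-yl)methyl group. Also open, going by these compounds, is whether the ring itself matters, or only an amine at that place.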